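A few compounds are considered here, and "the series" means these few. Any claim that something is new, unique, unknown or untested is made for them only; others in the source may bear on it.

Working notes on the series, read in a functional assay on HL-60 cells (Homo sapiens) for inhibition, read by MTT assay, with a stated time of 72 h; on this read-out higher numbers stand for weaker inhibition and lower numbers for stronger inhibition. Compound 1 `Cc1nc(-c2ccccc2)c(C(=O)N2CCN(c3cccc(C)c3C)CC2)o1` gives 35 nM, compound 2 `Cc1ccc(N2CCN(C(=O)c3oc(C)nc3-c3ccccc3)CC2)c(C)c1` gives 101 nM and compound 3 `CC(=O)Nc1cccc(N2CCN(C(=O)c3oc(C)nc3-c3ccccc3)CC2)c1` gives 329 nM. Compound 3 has the highest number of the three, so its inhibition is the weakest measured so far. Compound 4 `Cc1nc(-c2ccccc2)c(C(=O)N2CCN(c3ccc(C)c(C)c3)CC2)o1` keeps the shared core and has 3,4-dimethylphenyl in place of 3-acetamidophenyl on an amine nitrogen in a ring. The steps bearing on this change are a 9.4-fold higher number from compound 1 to compound 3 (0.97 log units; beyond the scatter) and a 3.3-fold higher number from compound 2 to compound 3 (0.51 log units; beyond the scatter), both beyond the scatter, with each dimethylphenyl compound lower than compound 3. The two dimethylphenyl compounds also differ from each other, by a 2.9-fold higher number from compound 1 to compound 2 (0.46 log units; beyond the scatter), so the placing of the methyl groups cannot be ignored. No 3,4-dimethylphenyl compound has been measured yet. A modest drop in this assay is therefore expected, and the estimated step is a 3.9-fold lower number from compound 3 to compound 4 (0.59 log units; beyond the scatter). For compound 4 the expected value is 85 nM, with an estimated range of 30 nM to 240 nM.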

Compound 4, half-maximal inhibitory concentration: 43 nM
Compound 4: middle estimate off by 2.0-fold (0.30 log units), on the high side; measured number inside the range.
By their numbers in this assay, from the lowest: compounds 1 and 4 (each within the scatter of the next); then compound 2; then compound 3.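

In this assay, putting 3,4-dimethylphenyl in place of 3-acetamidophenyl on the amine nitrogen in the ring gives a 7.7-fold lower number from compound 3 to compound 4 (0.88 log units; beyond the scatter) and brings the series back to the low numbers of the dimethylphenyl compounds. Methyl placing now reads less simply: 3,4-dimethylphenyl and 2,3-dimethylphenyl show a 1.2-fold higher number from compound 1 to compound 4 (0.09 log units; within the scatter) and cannot be told apart, whereas 3,4-dimethylphenyl in place of 2,4-dimethylphenyl gives a 2.3-fold lower number from compound 2 to compound 4 (0.37 log units; beyond the scatter), which leaves compound 2 apart from the other two dimethylphenyl compounds. Nothing at hand accounts for these differences.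

Still open, on these data alone, is how a phenyl bearing a single methyl, an amine or a carboxylic acid would read on this nitrogen. The step to compound 4 also does not separate the loss of the acetamide from the gain of the two methyl groups.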